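Thioether arm in place of the ethylpiperidine on compound 2

The compounds below may be only part of what the source reports. "The series", "measured", "known", "first", "only" and "open" are said of these compounds alone.

Measured so far:
- compound 1 `CC(C(=O)NCc1ccc(C(F)(F)F)cc1N1CCCCCCC1)c1ccc(NS(C)(=O)=O)c(F)c1`; in an assay on CHO cells for antagonist activity at transient receptor potential cation channel subfamily V member 1 (Homo sapiens), read by FLIPR (a higher number here means a weaker inhibitor, a lower number a stronger inhibitor), compound 1 gives 2.8 nM
- compound 2 `CCC1CCN(c2cc(C(F)(F)F)ccc2CNC(=O)C(C)c2ccc(NS(C)(=O)=O)c(F)c2)CC1`; in this assay compound 2 gives 0.7 nM
- compound 3 `CC(C)CCSc1cc(C(F)(F)F)ccc1CNC(=O)C(C)c1ccc(NS(C)(=O)=O)c(F)c1`; in this assay compound 3 gives 1.4 nM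

Compound 2 holds the lowest number of the three; compound 3 is nearest, a 2.0-fold higher number from compound 2 to compound 3 (0.30 log units; within the scatter), and compound 1 is furthest, a 4.0-fold lower number from compound 1 to compound 2 (0.60 log units; beyond the scatter) read in reverse. Compound 4 `CC(C(=O)NCc1ccc(C(F)(F)F)cc1SCc1ccco1)c1ccc(NS(C)(=O)=O)c(F)c1` has not been measured in this assay. It differs from compound 2 in one place: ((furan-2-yl)methyl)sulfanyl in place of 4-ethylpiperidin-1-yl on an aromatic carbon.

The step that bears most directly on this change is a 2.0-fold higher number from compound 2 to compound 3 (0.30 log units; within the scatter), where a chain bearing sulfur on the same aromatic carbon replaced the same 4-ethylpiperidin-1-yl and the number stayed within the scatter. The step of a 2.0-fold lower number from compound 1 to compound 3 (0.30 log units; within the scatter) likewise shows a sulfur-bearing chain at that position giving a number close to a ring-bearing group. Among the compounds with values here, no measured pair shows the ((furan-2-yl)methyl)sulfanyl group itself, so its effect is not known from the series. The expectation for this assay is therefore a small move, if any, with the number staying near compound 2 or drifting slightly upward toward compound 3, within the scatter: a 1.7-fold higher number from compound 2 to compound 4 (0.23 log units; within the scatter) is the expected step. For compound 4 the estimate in this assay is 1.2 nM, with a range from 0.4 nM to 3.5 nM.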

Compound 4, inhibition constant: 3.2 nM
Beside the measured number, compound 4's estimate is 2.7-fold (0.43 log units) below it, and the stated range covers the measured number.
By their numbers in this assay, from the lowest: compounds 2, 3, 1 and 4 (each within the scatter of the next, the first and the last beyond it).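

In this assay the sulfur link alone does not fix the number at this position: with the sulfur kept, the furan-2-yl end gives a 2.3-fold higher number from compound 3 to compound 4 (0.36 log units; beyond the scatter) and so the group at the end of the chain matters here. Measured against the 4-ethylpiperidin-1-yl group, the ((furan-2-yl)methyl)sulfanyl arm gives a 4.6-fold higher number from compound 2 to compound 4 (0.66 log units; beyond the scatter) and so, unlike the isopentylsulfanyl arm of compound 3, does not stay within the scatter of compound 2, while the step of a 1.1-fold higher number from compound 1 to compound 4 (0.06 log units; within the scatter) leaves it within the scatter of the eight-membered ring arm of compound 1. Nothing at hand explains why the furan-bearing arm behaves differently from the isopentylsulfanyl arm.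

The compounds shown do not separate the contribution of the furan ring from that of the methylene link to the sulfur, so a phenyl or thiophene ring on the same link, or a longer chain ending in furan-2-yl, would be the direct test. On these data alone, it also remains open whether an ether oxygen in place of the sulfur would leave the number of the furan-bearing arm unchanged.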